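A tert-Butyl Replaces Thiophene on a Shared Core

A few compounds are considered here, and "the series" means these few. Any claim that something is new, unique, unknown or untested is made for them only; others in the source may bear on it.

Of the compounds shown here, three on a shared core have been measured in an assay on isolated protein for inhibition of RAC-alpha serine/threonine-protein kinase (Homo sapiens), read by mobility shift assay, tested at 30 uM; on this read-out higher numbers stand for more inhibition at the one concentration tested (going by the name of the read-out) and lower numbers for less inhibition. Compound 1 `Cc1cc2[nH]nc(N)c2c(=O)[nH]1` gives -3%. Compound 2 `COc1cccc(-c2cc3[nH]nc(N)c3c(=O)[nH]2)c1` gives 4%. Compound 3 `Nc1n[nH]c2cc(-c3cccs3)[nH]c(=O)c12` gives 4%. Compound 3 is level with compound 2 at the digits shown, and the two of them together hold the highest of the three numbers; compound 1 lies furthest from compound 3, by a gap that stays within the scatter. Going by the values given here, the one step that differs in a single place, a number 7 percentage points higher from compound 1 to compound 3 (within the scatter), is likewise within the scatter, so none of the three compounds shows inhibition beyond noise in this assay.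

Compound 4 `CC(C)(C)c1cc2[nH]nc(N)c2c(=O)[nH]1` is the next compound, differing from compound 3 as follows: tert-butyl in place of thiophen-2-yl on an aromatic carbon

Among the compounds with values here, the only step that bears on this change is the one from compound 1 to compound 3, where a thiophen-2-yl stood in for a small alkyl group and the number moved by a number 7 percentage points higher from compound 1 to compound 3 (within the scatter). Compound 4 carries a tert-butyl at the same aromatic carbon, and because compound 1 with its methyl gave -3%, the expected change for compound 4 is a number 4 percentage points lower from compound 3 to compound 4 (within the scatter), no step beyond the scatter. Compound 4 is thus estimated at 0%, with a range from -10% to 10%.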

Compound 4, a percentage reported as inhibition, at one concentration (the size of the read-out at that concentration, not a potency): 3%
Beside the measured number, compound 4's estimate is 3 percentage points below it; the measured number falls inside the stated range.
By their numbers in this assay, from the lowest: compounds 1, 4, 2 and 3 (each within the scatter of the next).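

At the aromatic carbon next to the ring nitrogen, a tert-butyl, which has no ring, replaces the five-membered aromatic thiophen-2-yl, and this assay shows a number 1 percentage points lower from compound 3 to compound 4 (within the scatter) for this exchange, so removing the ring and its sulfur leaves no mark on this read-out at the one concentration tested. Set against the methyl, the tert-butyl gives a number 6 percentage points higher from compound 1 to compound 4 (within the scatter) and thereby adds a third kind of group, neither the small methyl nor an aromatic ring, to a position where methyl, thiophen-2-yl and tert-butyl all stay within the scatter of one another. No measurement at hand offers any explanation for this flat picture at the position.

On these data alone, what remains open is whether any group at this aromatic carbon can lift the number beyond the scatter, for example an amine, a carboxylic acid or a longer chain ending in one of these. It is also open whether the shared core can give real inhibition in this assay at all, since every compound shown so far stays close to zero.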